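The source may report more compounds than this note shows. Statements on the series, on what has been measured and on what is new or still open speak of the compounds shown alone.

Compound 1 `CCOc1ccc(Br)c(C(O)c2c(C)oc3c([C@H]4CCN(C)C[C@H]4O)c(O)cc(O)c3c2=O)c1`: 2%
Compound 2 `CN1CC[C@H](c2c(O)cc(O)c3c(=O)cc(/C=C/c4ccccc4)oc23)[C@H](O)C1`: 91%

In a functional assay on HL-60 cells (Homo sapiens) for inhibition, read by MTT assay, with a stated time of 48 h, tested at 10 uM (a lower number here means less inhibition of growth, a higher number more inhibition of growth at the concentration tested), compound 1 gives 2% and compound 2 gives 91%. Compound 2 stands highest of the two measured compounds, and the gap between the two lies beyond the scatter. Compound 3 `CN1CC[C@H](c2c(O)cc(O)c3c(=O)cc(/C=C/c4cccc(F)c4)oc23)[C@H](O)C1` differs from compound 2 by one change, fluoro in place of hydrogen on an aromatic carbon, turning phenyl to 3-fluorophenyl. For the measured compounds named here, no measured pair shows this change. With compound 2 already at 91%, little room remains upward, so no step beyond the scatter is expected in this assay, only an estimated a number 4 percentage points lower from compound 2 to compound 3 (within the scatter). For compound 3 the expected value is 87%, with an estimated range of 68% to 98%.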

Compound 3, percent growth inhibition at one concentration: 60%
Beside the measured number, compound 3's estimate is 27 percentage points above it; the whole stated range lies above it.
By their numbers in this assay, from the lowest: compound 1; then compound 3; then compound 2.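

In this assay, the aromatic ring of the 2-phenylethenyl group proves sensitive to a single heavy atom: turning phenyl to 3-fluorophenyl gives a number 31 percentage points lower from compound 2 to compound 3 (beyond the scatter). The earlier compounds shown here offered no measured view of any change on this ring. Nothing at hand accounts for the loss. As far as these compounds go, whether it belongs to fluoro alone or to any group at this carbon remains open, as a chloro or methoxy group there could show. From the compounds shown here alone, the effect of fluoro on the other carbons of this ring also stays open.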